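The compounds below may be only part of what the source reports. "The series", "measured", "known", "first", "only" and "open" are said of these compounds alone.

Of the compounds shown here, three with a shared core have been measured in a functional assay on CHO-K1 cells for antagonist activity at transient receptor potential cation channel subfamily V member 1 (Homo sapiens), read by FLIPR (on this read-out higher numbers stand for weaker inhibition and lower numbers for stronger inhibition), and they differ only in the group sitting on an aromatic carbon of the core. Compound 1 `Cc1ccc(Cl)cc1Nc1nc(C(F)(F)F)ccc1CNC(=O)C(C)c1ccc(NS(C)(=O)=O)c(F)c1` gives 14 nM. Compound 2 `CC(C(=O)NCc1ccc(C(F)(F)F)nc1N(C)C)c1ccc(NS(C)(=O)=O)c(F)c1` gives 19.1 nM. Compound 3 `CC(C(=O)NCc1ccc(C(F)(F)F)nc1N1CCC(=O)CC1)c1ccc(NS(C)(=O)=O)c(F)c1` gives 91 nM, the highest of the three numbers, and the step from compound 2 to compound 3 was a 4.8-fold higher number from compound 2 to compound 3 (0.68 log units; beyond the scatter) while that from compound 1 to compound 3 was a 6.5-fold higher number from compound 1 to compound 3 (0.81 log units; beyond the scatter). Compound 4 `CC(C(=O)NCc1ccc(C(F)(F)F)nc1N1CCCCCC1)c1ccc(NS(C)(=O)=O)c(F)c1` has not yet been measured. It differs from compound 3 by azepan-1-yl in place of 4-oxopiperidin-1-yl on an aromatic carbon. The two steps into compound 3 bear on this change: both show that the 4-oxopiperidin-1-yl group weakened inhibition against two other nitrogen-linked groups, one of them the small dimethylamino of compound 2, and the azepan-1-yl group likewise lacks the carbonyl. Compound 4 is therefore expected to give a lower number than compound 3, by a step of about a 3.0-fold lower number from compound 3 to compound 4 (0.48 log units; beyond the scatter), though not necessarily reaching the level of compound 2. The estimate for compound 4 in this assay is 30 nM, with a range from 10 nM to 100 nM.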

Compound 4, inhibition constant: 0.8 nM
Estimate against measurement, compound 4: 38-fold (1.57 log units) above, and the stated range ends above it.
By their numbers in this assay, from the lowest: compound 4; then compounds 1 and 2 (each within the scatter of the next); then compound 3.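

In this assay this position proves able to move the number much further than the earlier groups hinted, with a 110-fold lower number from compound 3 to compound 4 (2.06 log units; beyond the scatter) for a swap that leaves the heavy-atom count of the group unchanged. The azepan-1-yl group also stands clear of the two other nitrogen-linked groups, with a 24-fold lower number from compound 2 to compound 4 (1.38 log units; beyond the scatter) and an 18-fold lower number from compound 1 to compound 4 (1.24 log units; beyond the scatter) pointing the same way, so the level shared by compound 1 and compound 2 was not the lowest number this position can give. No measurement available here offers an explanation for a change of this size.

The swap enlarges the ring and removes the carbonyl together, and the compounds shown cannot tell these two changes apart. A plain piperidin-1-yl group would separate them, and an azocan-1-yl ring would show whether the trend continues with a still larger ring.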